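Halogen swap on the fused core: compound 2 to compound 3

The source may report more compounds than this note shows. Statements on the series, on what has been measured and on what is new or still open speak of the compounds shown alone.

Measured so far:
compound 1 `Brc1cccc2c1nnn2CC1CC1` — 70 nM
compound 2 `Brc1cc(Br)c2nnn(CC3CC3)c2c1` — 50 nM

In a functional assay on cells for positive allosteric modulation of metabotropic glutamate receptor 2 (Homo sapiens), read by fluorescence and calcium flux, with a stated time of 30 min (a lower number here means that less compound is needed, a higher number that more compound is needed for the effect), compound 2 gives 50 nM and compound 1 gives 70 nM; the two numbers sit within the scatter of each other, so neither stands apart. Among the measured compounds shown here, the single step measured, a 1.4-fold lower number from compound 1 to compound 2 (0.15 log units; within the scatter), comes from bromo entering for hydrogen on the six-membered ring and is itself within the scatter.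

Compound 3 `Clc1cc(Br)c2nnn(CC3CC3)c2c1` differs from compound 2 by chloro in place of bromo on an aromatic carbon. For the measured compounds named here, no measured step exchanges one halogen for another, so the only guidance is the bromo-for-hydrogen step from compound 1 to compound 2, which stayed within the scatter. A change of one halogen for another at the same place is smaller than adding a halogen, so in this assay no step beyond the scatter is expected. Compound 3 is therefore expected near 60 nM, with a range from 25 nM to 150 nM. The expected step of a 1.2-fold higher number from compound 2 to compound 3 (0.08 log units; within the scatter) is estimated to lie within the scatter.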

Compound 3, half-maximal effective concentration: 60 nM
For compound 3 middle estimate and measured number coincide at the digits printed; measured number inside the range.
By their numbers in this assay, from the lowest: compounds 2, 3 and 1 (each within the scatter of the next).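

In this assay, this position, para to a fused ring and meta to a bromo group, has now been read with a direct exchange of one halogen for another: a 1.2-fold higher number from compound 2 to compound 3 (0.08 log units; within the scatter). Set against hydrogen, chloro gives a similar reading, a 1.2-fold lower number from compound 1 to compound 3 (0.07 log units; within the scatter), so hydrogen, bromo and chloro at this one place do not separate from one another in compound 1, compound 2 and compound 3. No supporting data on these compounds bear on this result.

Open, going by these compounds, is whether anything other than a halogen at this position, such as an amine, a carboxylic acid or a longer chain, would give a step beyond the scatter. Also open, on these data alone, is what replacing the remaining bromo group would do, as that group is common to all three compounds.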